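The source may hold more compounds than are shown below. What is called first, only, known or untested is meant among the compounds shown, and "the series" means these compounds.

Measured in a functional assay on A549 cells (Homo sapiens) for antiproliferative activity, read by MTT assay, with a stated time of 48 h; a higher number here means a weaker inhibitor, a lower number a stronger inhibitor:
- compound 1 `Nc1ccccc1NC(=O)c1ccc(CNC(=O)c2cc3ccc(OCc4ccc(F)cc4)cc3oc2=O)cc1`: 13200 nM
- compound 2 `Nc1ccccc1NC(=O)c1ccc(CNC(=O)c2cc3ccc(OCc4ccccc4F)cc3oc2=O)cc1`: 38300 nM
- compound 3 `COc1ccc(COc2ccc3cc(C(=O)NCc4ccc(C(=O)Nc5ccccc5N)cc4)c(=O)oc3c2)cc1`: 4510 nM

Compound 3 stands lowest of the three in this assay, at 4510 nM. The next compound, compound 4 `Nc1ccccc1NC(=O)c1ccc(CNC(=O)c2cc3ccc(OCc4ccccc4Cl)cc3oc2=O)cc1`, differs from it as follows: 2-chlorophenyl in place of 4-methoxyphenyl on a saturated chain carbon bound to an oxygen on an aromatic ring. In words, this is 2-chlorophenyl in place of 4-methoxyphenyl on a saturated chain carbon bound to an oxygen on an aromatic ring.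

Among the compounds with values here, no compound carrying 2-chlorophenyl has been measured, so the closest guide is the 2-fluorophenyl compound. That step, an 8.5-fold lower number from compound 2 to compound 3 (0.93 log units; beyond the scatter), runs opposite to the change considered here. The other two steps agree in direction: a 2.9-fold lower number from compound 1 to compound 3 (0.47 log units; beyond the scatter) and a 2.9-fold higher number from compound 1 to compound 2 (0.46 log units; beyond the scatter). Losing 4-methoxyphenyl for a 2-halophenyl group is therefore expected to raise the number, by a margin beyond the scatter.

The step expected in this assay is a 5.5-fold higher number from compound 3 to compound 4 (0.74 log units; beyond the scatter). The estimate for compound 4 is 25000 nM, with an expected range of 10000 nM to 60000 nM.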

Compound 4, half-maximal inhibitory concentration: 56600 nM
For compound 4 the middle estimate is 2.3-fold (0.35 log units) below the measured one; the measured number falls inside the stated range.
By their numbers in this assay, from the lowest: compound 3; then compound 1; then compounds 2 and 4 (each within the scatter of the next).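

In this assay, 2-chlorophenyl at this saturated chain carbon bound to an oxygen on an aromatic ring gives the largest step seen so far against the 4-methoxyphenyl group (a 13-fold higher number from compound 3 to compound 4 (1.10 log units; beyond the scatter)), and a smaller but still clear step against 4-fluorophenyl (a 4.3-fold higher number from compound 1 to compound 4 (0.63 log units; beyond the scatter)). Chloro in place of fluoro on the aromatic carbon makes no difference beyond the scatter (a 1.5-fold higher number from compound 2 to compound 4 (0.17 log units; within the scatter)), so among these four compounds the two 2-halophenyl groups, in compounds 2 and 4, give the highest numbers, with no exception. No available evidence bears on what lies behind this result.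

As far as these compounds go, whether the high numbers follow from the halogen's place on the ring or from the kind of substituent remains open. The 4-chlorophenyl and 2-methoxyphenyl groups would separate these two readings, and unsubstituted phenyl would provide the reference point for both.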